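The source may report more compounds than this note shows. Statements on the series, on what has been measured and on what is new or still open speak of the compounds shown alone.

Working notes on the series in an ADME assay on a cell-free system (plasma, Homo sapiens) for protein binding. Compound 1 `CNc1nccc(N2CC[C@H](NC(=O)Nc3ccc(CN4CCC4)c(C(F)(F)F)c3)C2)n1` gives 86.3%. Compound 3 `CNc1nccc(N2CC[C@H](NC(=O)Nc3cccc(OC)c3)C2)n1` gives 96.7%. Compound 2 `CCNc1nccc(N2CC[C@H](NC(=O)Nc3ccc(Cl)c(C(F)(F)F)c3)C2)n1` reads > 99.9%, which is a limit of the assay and not a number. Its standing in the set is the limit of > 99.9% in this assay, at which 1 of the 3 values shown sits. Compound 4 `O=C(Nc1ccc(Cl)c(C(F)(F)F)c1)N[C@H]1CCN(c2ccncn2)C1` departs from compound 2 by one change, (hydrogen in place of ethylamino on an aromatic carbon), with hydrogen in place of ethylamino, between two ring nitrogen atoms. Among the measured compounds shown here, no measured pair isolates this change. A modest fall in this assay is expected, though the starting point for compound 2 is only the limit > 99.9%. The expected move is an at least 15-fold higher unbound fraction from compound 2 to compound 4 (1.17 log units; beyond the scatter). For compound 4 the estimated value is 98.5%, with an expected range of 95.5% to 99.7%.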

Compound 4, plasma protein binding: 99.3%
Beside the measured number, compound 4's estimate is 2.1-fold (0.33 log units) (unbound fraction) above it, and the stated range covers the measured number.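

In this assay, among the compounds shown here, this is the first pair differing in one place, and it shows that the position between two ring nitrogen atoms affects the read-out: hydrogen in place of ethylamino gives an at least 7.0-fold higher unbound fraction from compound 2 to compound 4 (0.84 log units; beyond the scatter). Even without ethylamino, compound 4 gives 99.3%. Compound 2 gives only a limit of the assay and not a number, so the true step may be larger: the limit of > 99.9% in this assay, at which 1 of the 4 values shown sits.

The compounds shown leave open how an unsubstituted amine or a longer alkylamino chain at this position would read. Going by these compounds, whether the same change carries over to the settings of compound 1 and compound 3 also remains open.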